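Truncation of a triazole side chain in a cell growth assay

The source may hold more compounds than are shown below. What is called first, only, known or untested is meant among the compounds shown, and "the series" means these compounds.

Measured compounds:
- compound 1 `Cc1ccc(OCc2cn(-c3ccc(NS(C)(=O)=O)c(Oc4ccccc4)c3)nn2)cc1`: 15800 nM
- compound 2 `Cc1cc(OCc2cn(-c3ccc(NS(C)(=O)=O)c(Oc4ccccc4)c3)nn2)ccc1Cl`: 7900 nM
- compound 3 `CS(=O)(=O)Nc1ccc(-n2cc(COc3ccc([N+](=O)[O-])cc3)nn2)cc1Oc1ccccc1`: "not determined" (no result reported)

The shared core carries a methanesulfonamide and a phenoxy group, with a triazole bearing a side chain. Within the data shown here, in a functional assay on HeLa cells (Homo sapiens) for inhibition, read by MTT assay, with a stated time of 48 h (on this read-out higher numbers stand for weaker inhibition and lower numbers for stronger inhibition), compound 1 gives 15800 nM and compound 2 gives 7900 nM; the only step between measured compounds, a 2.0-fold lower number from compound 1 to compound 2 (0.30 log units; within the scatter), exchanges 4-chloro-3-methylphenyl for 4-methylphenyl on an oxygen on a saturated carbon and lies within the scatter. Compound 3 has no number in this assay, so it cannot be placed against the other two.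

Compound 4 `CS(=O)(=O)Nc1ccc(-n2cc(-c3ccccc3)nn2)cc1Oc1ccccc1` differs from compound 3 by phenyl in place of (4-nitrophenoxy)methyl on an aromatic carbon. Among the measured compounds shown here, no measured step touches this position: the one known step alters the aryl group on the oxygen and leaves the linker intact, so it gives no guide to the size or direction of this change. All that the data offer is the weak inhibition of compounds 1 and 2, and the estimate for compound 4 therefore rests on them alone, with a wide range.

Compound 4 is expected to give about 15000 nM in this assay, between 3000 nM and 70000 nM.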

Compound 4, half-maximal inhibitory concentration: 21900 nM
Compound 4: the middle estimate sits 1.5-fold (0.16 log units) below what was measured; measured number inside the range.
By their numbers in this assay, from the lowest: compounds 2, 1 and 4 (each within the scatter of the next, the first and the last beyond it).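

In this assay, the side chain on this aromatic carbon can be cut back to phenyl and a measurable number remains. Set against the (4-methylphenoxy)methyl group, the shorter group stays within the scatter (a 1.4-fold higher number from compound 1 to compound 4 (0.14 log units; within the scatter)), while set against the (4-chloro-3-methylphenoxy)methyl group it gives a modest loss (a 2.8-fold higher number from compound 2 to compound 4 (0.44 log units; beyond the scatter)), so the size of this change depends on which group leaves. Compound 3 has no number, so the step from it cannot be read, and nothing on hand explains these results.

The compounds shown leave open whether an amine, a carboxylic acid or a longer chain on this carbon would move the number. They also leave open whether a substituted phenyl placed directly on this carbon would follow the same course as the groups on the longer side chain.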